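The source may report more compounds than this note shows. Statements on the series, on what has been measured and on what is new or still open speak of the compounds shown alone.

Measured so far in a functional assay on WM 266-4 cells (Homo sapiens) for antiproliferative activity, read by MTT assay, with a stated time of 24 h; on this read-out higher numbers stand for weaker inhibition of growth and lower numbers for stronger inhibition of growth:
compound 1 `COc1ccc(C2CC(c3ccc4c(c3)OCCO4)=NN2c2ccccc2)cc1OC` gives 2160 nM
compound 2 `Fc1ccc(C2CC(c3ccc4c(c3)OCCO4)=NN2c2ccccc2)cc1` gives 6050 nM
compound 3 `Brc1ccc(C2CC(c3ccc4c(c3)OCCO4)=NN2c2ccccc2)cc1` gives 3010 nM

Compound 2 carries the highest of the three numbers; compound 3 sits nearest, the gap being a 2.0-fold lower number from compound 2 to compound 3 (0.30 log units; within the scatter), and compound 1 furthest, the gap being a 2.8-fold higher number from compound 1 to compound 2 (0.45 log units; beyond the scatter).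

Compound 4 `c1ccc(C2CC(c3ccc4c(c3)OCCO4)=NN2c2ccccc2)cc1` is not yet measured. Against compound 2 it shows (hydrogen in place of fluoro on an aromatic carbon); cut one bond further out, the change reads 4-fluorophenyl to phenyl.

Within the data shown here, no measured step removes a substituent outright, so only the two steps touching compound 2 bear on this. Swapping the halogen gave a 2.0-fold lower number from compound 2 to compound 3 (0.30 log units; within the scatter), and the larger change to 3,4-dimethoxyphenyl gave a 2.8-fold higher number from compound 1 to compound 2 (0.45 log units; beyond the scatter). The expected step for compound 4 is therefore a 1.2-fold lower number from compound 2 to compound 4 (0.08 log units; within the scatter), small, with no clear direction beyond the scatter.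

Compound 4 is estimated at 5000 nM, in the range 2000 nM to 12000 nM.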

Compound 4, concentration for 50% growth inhibition: 22400 nM
Compound 4: middle estimate off by 4.5-fold (0.65 log units), on the low side; measured number above the stated range.
By their numbers in this assay, from the lowest: compounds 1, 3 and 2 (each within the scatter of the next, the first and the last beyond it); then compound 4.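

In this assay the bare phenyl stands apart from all three substituted rings, with a 3.7-fold higher number from compound 2 to compound 4 (0.57 log units; beyond the scatter) and a 7.4-fold higher number from compound 3 to compound 4 (0.87 log units; beyond the scatter) and a 10-fold higher number from compound 1 to compound 4 (1.02 log units; beyond the scatter) as the steps. Having a substituent at this place on the ring thus counts for more here than which halogen it is: fluoro and bromo lie within the scatter of each other, yet each stands clearly apart from hydrogen. Nothing at hand accounts for this.

Open, from the compounds shown here alone, is whether a single methoxy, an amine or a carboxylic acid at this place would keep the lower numbers of the halogens. Also open, going by these compounds, is whether the gain from a substituent holds with any other group on the rest of the core.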